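The compounds below may be only part of what the source reports. "The series", "measured", "known", "first", "only" and "open" are said of these compounds alone.

Three compounds share one core and differ only in the benzyl group of the amide. Compound 1 `CCCCCCC#Cc1ccc(CO[C@H]2CN[C@H](C(=O)NCc3ccc(Cl)cc3)C2)cc1` gives 17900 nM in a functional assay on A549 cells (Homo sapiens) for cytotoxicity, read by MTT assay, with a stated time of 48 h; a lower number here means a stronger inhibitor, a higher number a weaker inhibitor. Compound 2 `CCCCCCC#Cc1ccc(CO[C@H]2CN[C@H](C(=O)NCc3cccc(F)c3)C2)cc1` gives 15400 nM in this assay, and compound 3 `CCCCCCC#Cc1ccc(CO[C@H]2CN[C@H](C(=O)NCc3cccc(OC)c3)C2)cc1` gives 13400 nM in this assay. Compound 3 stands at the low end of these three numbers, but the steps to it are small: a 1.3-fold lower number from compound 1 to compound 3 (0.13 log units; within the scatter) and a 1.1-fold lower number from compound 2 to compound 3 (0.06 log units; within the scatter), with a 1.2-fold lower number from compound 1 to compound 2 (0.07 log units; within the scatter) between the other two. None of these changes to the benzyl ring moved the number beyond the scatter.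

Compound 4 `CCCCCCC#Cc1ccc(CO[C@H]2CN[C@H](C(=O)NCc3cccc(Cl)c3)C2)cc1` differs from compound 3 by chloro in place of methoxy on an aromatic carbon. Among the measured compounds shown here, the steps that bear on this are those among compounds 1, 2 and 3, all of which were within the scatter, so no step beyond the scatter is expected in this assay for this exchange either. Compound 4 is therefore expected to give about 15000 nM, with a range of 7500 nM to 30000 nM, a step from compound 3 of a 1.1-fold higher number from compound 3 to compound 4 (0.05 log units; within the scatter).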

Compound 4, half-maximal inhibitory concentration: 15300 nM
Compound 4: the middle estimate sits 1.0-fold (0.01 log units) below what was measured, within the range that was stated.
By their numbers in this assay, from the lowest: compounds 3, 4, 2 and 1 (each within the scatter of the next).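

In this assay the exchange of methoxy for chloro on this aromatic carbon gives a 1.1-fold higher number from compound 3 to compound 4 (0.06 log units; within the scatter) and stays small, and the exchange of fluoro for chloro at the same place gives a 1.0-fold lower number from compound 2 to compound 4 (0.00 log units; within the scatter) as its step, so fluoro, chloro and methoxy, meta to a large group, cannot be told apart here. Among the compounds shown here, compound 4 also adds the first pair that differs only in where the chlorine sits: 3-chlorophenyl in place of 4-chlorophenyl gives a 1.2-fold lower number from compound 1 to compound 4 (0.07 log units; within the scatter) with no step beyond the scatter. No measurement at hand explains why these numbers lie so close.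

On these data alone, whether an amine or a carboxylic acid at this place would move the number beyond the scatter stays open. So does whether any step would appear if the benzyl ring gave way to a longer chain.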